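The compounds below may be only part of what the source reports. "The series", "measured", "known", "first", "only" and "open" are said of these compounds alone.

In a functional assay on HepG2 cells (Homo sapiens) for antiproliferative activity, read by MTT assay, with a stated time of 24 h (a higher number here means a weaker inhibitor, a lower number a stronger inhibitor), three compounds with a shared core differ only in the group on a saturated chain carbon bound to an oxygen on an aromatic ring. Compound 1 `C=CCOc1ccc2c(=O)c(-c3cc(OC)c(OC)cc3OC)coc2c1` gives 3450 nM, compound 2 `C#CCOc1ccc2c(=O)c(-c3cc(OC)c(OC)cc3OC)coc2c1` gives 4950 nM, and compound 3 `COc1cc(OC)c(-c2coc3cc(OCc4ccc(F)cc4)ccc3c2=O)cc1OC` gives 1000 nM. That makes compound 3 the strongest inhibitor of the three.

Compound 4 `COc1cc(OC)c(-c2coc3cc(OCc4ccccc4C(F)(F)F)ccc3c2=O)cc1OC` changes that same place once more: 2-(trifluoromethyl)phenyl in place of 4-fluorophenyl on a saturated chain carbon bound to an oxygen on an aromatic ring. Put simply, 2-(trifluoromethyl)phenyl stands in place of 4-fluorophenyl.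

Among the measured compounds shown here, three measured steps touch this place. Between the two smaller groups, a 1.4-fold higher number from compound 1 to compound 2 (0.16 log units; within the scatter) stays within the scatter. Bringing in the 4-fluorophenyl gave modest gains, seen in a 3.5-fold lower number from compound 1 to compound 3 (0.54 log units; beyond the scatter) and in a 5.0-fold lower number from compound 2 to compound 3 (0.69 log units; beyond the scatter). Those two steps introduced the ring, whereas here one six-membered aromatic ring of carbon only leaves and another enters. For the measured compounds named here, no measured step swaps one such ring for another, so the data give no direct guide to the direction. The gain seen with compound 3 is therefore expected to be largely kept, with no shift beyond the scatter in this assay.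

The expected change is a 1.2-fold higher number from compound 3 to compound 4 (0.08 log units; within the scatter), a small step with an uncertain sign. For compound 4 the estimated value is 1200 nM, with an expected range from 400 nM to 3500 nM.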

Compound 4, half-maximal inhibitory concentration: 6550 nM
Compound 4: middle estimate off by 5.5-fold (0.74 log units), on the low side; measured number above the stated range.
By their numbers in this assay, from the lowest: compound 3; then compounds 1, 2 and 4 (each within the scatter of the next).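

In this assay, exchanging one aromatic ring for another at this position is not a neutral change: 2-(trifluoromethyl)phenyl in place of 4-fluorophenyl gives a 6.6-fold higher number from compound 3 to compound 4 (0.82 log units; beyond the scatter), so the gain seen with compound 3 does not come with just any such ring on the saturated chain carbon. The new ring also shows no separation from the smaller groups, with a 1.3-fold higher number from compound 2 to compound 4 (0.12 log units; within the scatter) against ethynyl and a 1.9-fold higher number from compound 1 to compound 4 (0.28 log units; within the scatter) against vinyl, so having a ring at this position is not enough to improve on those two groups. The names 4-fluorophenyl and 2-(trifluoromethyl)phenyl show that the substituent and its numbered place on the ring differ together, so this single step cannot be assigned to either difference alone.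

Nothing measured here explains why the two rings differ so clearly in this assay. As far as these compounds go, it remains open whether plain phenyl, 4-(trifluoromethyl)phenyl or 2-fluorophenyl would match compound 3, which would help separate the substituent from its place, and whether a ring carrying an amine or a carboxylic acid would be tolerated here.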